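Chloro in place of methyl: compound 3 projected

The source may hold more compounds than are shown below. What is called first, only, known or untested is meant among the compounds shown, and "the series" means these compounds.

Measured so far:
compound 1 `Cc1ccccc1[C@H]1COC(N)=N1`, 63 nM
compound 2 `Cc1cc(Cl)ccc1[C@H]1COC(N)=N1`, 1 nM

In a functional assay on HEK293 cells for agonist activity at trace amine-associated receptor 1 (Rattus norvegicus), read by cAMP accumulation, with a stated time of 30 min (a higher number here means that more compound is needed for the effect, a lower number that less compound is needed), compound 1 gives 63 nM, the highest of the two numbers; its nearest neighbour is compound 2, with a 63-fold lower number from compound 1 to compound 2 (1.80 log units; beyond the scatter). That single step adds a chloro on an aromatic carbon while the methyl stays in place.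

Compound 3 `NC1=N[C@@H](c2ccccc2Cl)CO1` is not yet measured. It differs from compound 1 by chloro in place of methyl on an aromatic carbon. Among the compounds with values here, no measured pair exchanges one group for another at the same aromatic carbon, so the only comparison available is the addition of chloro elsewhere on the ring, which produced a 63-fold lower number from compound 1 to compound 2 (1.80 log units; beyond the scatter). That step is large, but it is an addition, not a replacement, and a chloro at a different position; it does not carry over directly.

Within the data shown here, with no closer precedent, a step from compound 1 to compound 3 of a 1.6-fold lower number from compound 1 to compound 3 (0.20 log units; within the scatter) in this assay is expected, within or only modestly beyond the scatter. Compound 3 is therefore estimated at 40 nM, with a range of 8 nM to 200 nM.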

Compound 3, half-maximal effective concentration: 87 nM
Compound 3: middle estimate off by 2.2-fold (0.34 log units), on the low side; measured number inside the range.
By their numbers in this assay, from the lowest: compound 2; then compounds 1 and 3 (each within the scatter of the next).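

In this assay, chloro in place of methyl on an aromatic carbon, ortho to a group of 6 heavy atoms, gives a 1.4-fold higher number from compound 1 to compound 3 (0.14 log units; within the scatter), so at this position the exchange of one group of one heavy atom for another stays inside the scatter. The earlier step, a 63-fold lower number from compound 1 to compound 2 (1.80 log units; beyond the scatter), was an addition of chloro at another aromatic carbon with the methyl kept, and the new pair shows that a chloro on the ring does not bring a large step in every placement: among these three compounds, the large step belongs to that addition alone. No available evidence bears on why methyl and chloro read alike at this position.

The compounds shown leave open whether methyl and chloro remain interchangeable at this position when the second chloro of compound 2 is present, since the exchange has been read only on the ring of compound 1. They also leave open how far this position accepts other groups, such as methoxy, an amine or a longer chain, and how the number responds to hydrogen there.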